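A few compounds are considered here, and "the series" means these few. Any claim that something is new, unique, unknown or untested is made for them only; others in the source may bear on it.

Measured in a functional assay on CCRF-CEM cells (Homo sapiens) for inhibition (on this read-out higher numbers stand for weaker inhibition and lower numbers for stronger inhibition), so far:
- compound 1 `O=C1CCCCC/C1=C\c1ccccc1` gives 110000 nM
- compound 2 `Cc1ccc(/C=C2\CCCCCC2=O)cc1` gives > 500000 nM, which is a limit and not a number

Compound 2 therefore has no exact place on the scale, only that limit. The next compound is compound 3 `CN(C)c1ccc(/C=C2\CCCCCC2=O)cc1`, which carries dimethylamino in place of methyl on an aromatic carbon. Among the measured compounds shown here, only one measured step bears on this change, an at least 4.5-fold higher number from compound 1 to compound 2 (0.65 log units; beyond the scatter), and it brought in the methyl that now leaves. That single step is thin guidance, since dimethylamino is a different group from the hydrogen of compound 1. A move to a lower number is still expected, and the estimated step is an at least 2.5-fold lower number from compound 2 to compound 3 (0.39 log units; beyond the scatter), though it could prove smaller. For compound 3 the expected value is 200000 nM, with an estimated range of 50000 nM to 600000 nM.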

Compound 3, half-maximal inhibitory concentration: 45100 nM
The estimate for compound 3 lay 4.4-fold (0.65 log units) above the measured number; measured number below the stated range.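

Placing dimethylamino where compound 2 has methyl gives an at least 11-fold lower number from compound 2 to compound 3 (1.04 log units; beyond the scatter) in this assay. Set against the plain hydrogen, dimethylamino gives a 2.4-fold lower number from compound 1 to compound 3 (0.39 log units; beyond the scatter), so a group on this aromatic carbon need not weaken inhibition as methyl did, and the outcome depends on which group sits there. Compound 2 holds a limit and not a number, so the step away from it has only a minimum size and its full size cannot be read: the limit of > 500000 nM in this assay, at which 1 of the 3 values shown sits.

On these data alone, with only hydrogen, methyl and dimethylamino at this place, it remains open whether the nitrogen or the two methyl groups on it matter more, which a simple amino group or a methoxy group could help to separate. As far as these compounds go, it is also open whether a carboxylic acid or a longer chain here would strengthen or weaken inhibition.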